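A few compounds are considered here, and "the series" means these few. Any claim that something is new, unique, unknown or untested is made for them only; others in the source may bear on it.

In an assay for inhibition of malate dehydrogenase, cytoplasmic (Homo sapiens), with a stated time of 30 min (a lower number here means a stronger inhibitor, a higher number a weaker inhibitor), compound 1 `COC(=O)c1cccc(NC(=O)COc2ccc(C(C)(C)CC(C)(C)C)cc2)c1` gives 6650 nM.
Compound 2 `C#CCN1CCN(C(=O)COc2ccc(C(C)(C)CC(C)(C)C)cc2)CC1` gives only a limit here, > 40000 nM.
Compound 3 `CN1CCN(c2ccc(NC(=O)COc3ccc(C(C)(C)CC(C)(C)C)cc3)cc2)CC1` gives 3000 nM.

Compound 3 holds the lowest of the two numbers in this assay. Its nearest neighbour is compound 1, whose number is higher by a gap that lies beyond the usual scatter, so compound 3 is the stronger inhibitor of the two. The third value is a limit rather than a number: compound 2 sits at the limit of > 40000 nM in this assay, at which 1 of the 3 values shown sits, and nothing more can be said of it.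

Compound 4 `CC(C)(C)CC(C)(C)c1ccc(OCC(=O)Nc2ccc(C(F)(F)F)cc2)cc1` has not yet been measured in this assay. It differs from compound 3 in one place: trifluoromethyl in place of 4-methylpiperazin-1-yl on an aromatic carbon. Going by the values given here, no pair of measured compounds differing in a single place is available, so the size of this step cannot be read off from the data.

Compound 3, with 3000 nM, is the closest point of reference, and compound 1 shows that a small substituent on the anilide ring still gives a measurable number. A modest step toward a weaker inhibitor, or none beyond the scatter, is expected. The step of a 1.7-fold higher number from compound 3 to compound 4 (0.22 log units; within the scatter) that this estimate means is expected to be small. Compound 4 is therefore estimated at 5000 nM, within a range from 1500 nM to 20000 nM.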

Compound 4, half-maximal inhibitory concentration: 3440 nM
Compound 4: middle estimate off by 1.5-fold (0.16 log units), on the high side, within the range that was stated.
By their numbers in this assay, from the lowest: compounds 3, 4 and 1 (each within the scatter of the next, the first and the last beyond it). At a limit, above all of these: compound 2.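

In this assay, going by these compounds alone, the exchange of 4-methylpiperazin-1-yl for trifluoromethyl on an aromatic carbon, para to a large group, gives a 1.1-fold higher number from compound 3 to compound 4 (0.06 log units; within the scatter), the first step that can be read at a single place. For this pair, then, a six-membered non-aromatic ring with hetero atoms at this position is not needed for a number of this size: trifluoromethyl, which has no ring and no hydrogen-bond acceptors, serves within the scatter, so the two groups cannot be told apart here. Nothing measured among the compounds shown gives a cause for this result.

Still open, from the compounds shown here alone, is whether the position stays as undemanding for other groups, such as a carboxylic acid, a primary amine, a nitrile or a single fluorine, or whether one of these would move the number beyond the scatter. Also open, going by these compounds, is whether a tert-butyl group in place of the branched alkyl chain of the shared core would leave the number of compound 3 or compound 4 where it stands.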